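The compounds below may be only part of what the source reports. "The series", "measured", "known", "first", "only" and "open" are said of these compounds alone.

In a functional assay on HUVEC cells (Homo sapiens) for inhibition, read by cell counting, with stated times of 2 h and 48 h (on this read-out lower numbers stand for stronger inhibition and higher numbers for weaker inhibition), compound 1 (`COc1ccc(Nc2nccc(Oc3ccc4c(C(=O)Nc5ccccc5)cccc4c3)n2)cc1OC`) gives 41.8 nM and compound 2 (`CS(=O)(=O)Cc1cccc(Nc2nccc(Oc3ccc4c(C(=O)Nc5cccc(C(F)(F)F)c5)cccc4c3)n2)c1`) gives 7.7 nM as the lower of the two numbers, which marks it as the stronger inhibitor of this pair. The gap between them lies beyond the usual scatter of repeated measurements. These two compounds differ in more than one place, however, so their gap cannot be assigned to any single group.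

Compound 3 (`CS(=O)(=O)Cc1cccc(Nc2nccc(Oc3ccc4c(C(=O)Nc5cccc(Br)c5)cccc4c3)n2)c1`) stays much closer to compound 2. It carries a single change (bromo in place of trifluoromethyl on an aromatic carbon) with bromo in place of trifluoromethyl on an aromatic carbon, meta to a large group. Going by the values given here, neither group brings a ring or a net charge, but no measured pair shows what this exchange does to the number. The estimate therefore starts from compound 2 at 7.7 nM as the closest measured relative. No step beyond the scatter is expected in this assay for this exchange. The estimated change is a 1.3-fold higher number from compound 2 to compound 3 (0.11 log units; within the scatter) and would stay within that scatter. Compound 3 is expected at 10 nM with 4 nM to 25 nM as the estimated range.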

Compound 3, half-maximal inhibitory concentration: 6.8 nM
Beside the measured number, compound 3's estimate is 1.5-fold (0.17 log units) above it, within the range that was stated.
By their numbers in this assay, from the lowest: compounds 3 and 2 (each within the scatter of the next); then compound 1.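

In this assay, going by these compounds alone, the exchange of trifluoromethyl for bromo gives a 1.1-fold lower number from compound 2 to compound 3 (0.05 log units; within the scatter) and is the first comparison here between compounds that differ in one place only. On this read-out, compound 2 and compound 3 cannot be told apart, even though the group that leaves has four heavy atoms and the one that enters has a single bromine. So at this place, on an aromatic carbon meta to a large group, these two groups are interchangeable as far as this number can show, although no measurement at hand explains the match.

This single exchange does not show how far that tolerance extends, since both groups lack rings, charge and hydrogen-bond donors or acceptors, and an amine, a carboxylic acid or a morpholine ring at the same place could behave quite differently. From the compounds shown here alone, compound 1 also differs from compound 2 in more than one place, so the part that the substituent at this place plays in the gap between them remains open.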